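Chlorine position on the benzamide ring in a sulfonamide series

The compounds below may be only part of what the source reports. "The series", "measured", "known", "first", "only" and "open" are said of these compounds alone.

Two amides sharing one core have been measured in a functional assay on the whole organism for inhibition, with Mus musculus as the target, with stated times of 30 min and 2 h, at a dose of 10 mg/kg by the intraperitoneal route; a lower number here means less inhibition, a higher number more inhibition at the dose given (going by the name of the read-out). Compound 1 `COc1cccc(C(=O)NCc2ccc(CNS(=O)(=O)c3ccc(C)cc3)cc2)c1` gives 28% there. For the measured compounds named here, compound 2 `Cc1ccc(S(=O)(=O)NCc2ccc(CNC(=O)c3ccc(Cl)cc3)cc2)cc1` gives 50% in this assay, the higher of the two numbers; the single recorded step, a number 22 percentage points higher from compound 1 to compound 2 (beyond the scatter), lies beyond the scatter. Compound 3 `Cc1ccc(S(=O)(=O)NCc2ccc(CNC(=O)c3ccccc3Cl)cc2)cc1` is the next member, not yet measured in this assay. Its change from compound 2 is 2-chlorophenyl in place of 4-chlorophenyl on a carbonyl carbon. Going by the values given here, no measured step concerns the position of a chlorine on this ring; the only step available swaps one ring for another and says little about moving the chlorine. The working expectation is therefore a step within the scatter, with the estimate for compound 3 set at a number 10 percentage points lower from compound 2 to compound 3 (within the scatter) in this assay, carrying a wide range. Compound 3 is estimated at 40%, between 18% and 60%.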

Compound 3, a percentage reported as inhibition, in the whole organism at one dose (the size of the read-out at that dose, not a potency): 26%
Compound 3: the middle estimate sits 14 percentage points above what was measured; the range from low to high includes it.
By their numbers in this assay, from the lowest: compounds 3 and 1 (each within the scatter of the next); then compound 2.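

In this assay the position of the chlorine on this ring matters: with the same atoms joined differently, 2-chlorophenyl in place of 4-chlorophenyl on the carbonyl carbon gives a number 24 percentage points lower from compound 2 to compound 3 (beyond the scatter). Chlorine alone therefore does not carry the higher reading of compound 2, since the 2-chlorophenyl amide stands level with the 3-methoxyphenyl amide, with a number 2 percentage points lower from compound 1 to compound 3 (within the scatter). Nothing available accounts for the gap between the two chlorine positions.

On these data alone, whether the reading of compound 2 depends on chlorine itself or on any group at that place remains open; a bromine or a methyl group in place of the chlorine of 4-chlorophenyl would separate the two. All three readings also come from one dose, so they give the size of the effect at that dose and not a potency.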